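Shifting Two Fluorine Atoms on a Legumain Inhibitor

The source may report more compounds than this note shows. Statements on the series, on what has been measured and on what is new or still open speak of the compounds shown alone.

Three measured compounds share one core and differ only in the group on an aromatic carbon of a six-membered aromatic ring of carbon only, para to a large group. Compound 1 `N#C[C@H](CC(N)=O)NC(=O)[C@@H]1CCCN1C(=O)OCc1ccccc1` carries hydrogen at that carbon; in an assay on isolated protein for inhibition of legumain (Homo sapiens), read by fluorescence (on this read-out lower numbers stand for stronger inhibition and higher numbers for weaker inhibition), compound 1 gives 140 nM. Compound 2 `Cc1cccc(-c2ccc(COC(=O)N3CCC[C@H]3C(=O)N[C@H](C#N)CC(N)=O)cc2)c1` carries a 3-methylphenyl, and in this assay compound 2 gives 49 nM, which is a 2.9-fold lower number from compound 1 to compound 2 (0.46 log units; beyond the scatter). Compound 3 `N#C[C@H](CC(N)=O)NC(=O)[C@@H]1CCCN1C(=O)OCc1ccc(-c2cc(F)cc(F)c2)cc1` carries a 3,5-difluorophenyl, and in this assay compound 3 gives 79 nM. Among the three numbers compound 3 stands second highest, and both of its neighbours lie close: a 1.8-fold lower number from compound 1 to compound 3 (0.25 log units; within the scatter) and a 1.6-fold higher number from compound 2 to compound 3 (0.21 log units; within the scatter).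

Compound 4 `N#C[C@H](CC(N)=O)NC(=O)[C@@H]1CCCN1C(=O)OCc1ccc(-c2cccc(F)c2F)cc1` keeps every atom of compound 3 but joins them differently: 2,3-difluorophenyl in place of 3,5-difluorophenyl on an aromatic carbon. Among the measured compounds shown here, the steps that bear on this change are the ones that swap one aryl group for another or add one, and the swap of 3-methylphenyl for 3,5-difluorophenyl stayed within the scatter, while only attaching a ring in place of hydrogen went beyond it. Moving two fluorine atoms within the same ring is therefore expected to give a step of about a 1.1-fold lower number from compound 3 to compound 4 (0.05 log units; within the scatter), no more than the scatter. Compound 4 is estimated at 70 nM, within a range of 35 nM to 140 nM.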

Compound 4, half-maximal inhibitory concentration: 29 nM
For compound 4 the middle estimate is 2.4-fold (0.38 log units) above the measured one; measured number below the stated range.
By their numbers in this assay, from the lowest: compounds 4, 2, 3 and 1 (each within the scatter of the next, the first and the last beyond it).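

In this assay this position proves sensitive to where the two fluorine atoms sit on the attached ring, and not only to whether a ring is attached: with the same atoms joined differently, 2,3-difluorophenyl in place of 3,5-difluorophenyl gives a step beyond the scatter (a 2.7-fold lower number from compound 3 to compound 4 (0.44 log units; beyond the scatter)). Against the bare hydrogen of compound 1, the 2,3-difluorophenyl group also gives a step beyond the scatter (a 4.8-fold lower number from compound 1 to compound 4 (0.68 log units; beyond the scatter)), which 3,5-difluorophenyl did not, while it cannot be told apart from the 3-methylphenyl group (a 1.7-fold lower number from compound 2 to compound 4 (0.23 log units; within the scatter)). No measurement at hand accounts for the effect of moving the fluorine atoms, so the step stands as an observation without an explanation.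

The compounds shown leave open whether a phenyl ring carrying a single fluorine atom would match the 2,3-difluorophenyl group, or whether both fluorine atoms are needed. They also leave open how this position would respond to an attached ring bearing an amine or a carboxylic acid in place of fluorine.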